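A cyclopentyl swap on compound 2

The compounds below may be only part of what the source reports. "The series", "measured", "known", "first", "only" and "open" are said of these compounds alone.

Values in an ADME assay on HepG2 cells (Homo sapiens) for cytotoxicity (a higher number here means that more compound is tolerated, a lower number that less compound is tolerated), for the two measured compounds:
- Compound 1 `CN(C)CC#Cc1cc2ncnc(Nc3ccc(OCc4cccc(F)c4)c(Cl)c3)c2s1` gives > 32 uM as a limit of the assay, not a number
- Compound 2 `CN1CCN(CC#Cc2ccc3ncnc(Nc4ccc(OCc5cccc(F)c5)c(Cl)c4)c3c2)CC1` gives 8.2 uM as a number

Going by the values given here, compound 2 holds the only actual number in this assay so far. Compound 3 `Fc1cccc(COc2ccc(Nc3ncnc4ccc(C#CC5CCCC5)cc34)cc2Cl)c1` is still unmeasured and carries cyclopentyl in place of (4-methylpiperazin-1-yl)methyl on a triple-bonded carbon. Among the compounds with values here, no measured single-change step is available as a guide. The upward lean in this expectation rests on compound 1, whose reading (> 32 uM) is a limit. A small upward move is expected, with an estimated size of (a 2.2-fold higher number from compound 2 to compound 3 (0.34 log units; beyond the scatter)). The value expected for compound 3 is 18 uM within an estimated range from 7 uM to 32 uM in this measurement.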

Compound 3, half-maximal toxic concentration: > 3 uM
Compound 3: a limit, no number; the forecaster's own chance of this, stated with the estimate: 35%; the middle value is on the limit's open side.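

In this assay, going by these compounds alone, compound 3 gives > 3 uM as a limit and not a number, so no step from compound 2 to it can be read. Going by these compounds, whether cyclopentyl in place of (4-methylpiperazin-1-yl)methyl raises or lowers the number stays open.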